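Amide aryl swap on the shared core

The source may hold more compounds than are shown below. What is called first, only, known or untested is meant among the compounds shown, and "the series" means these compounds.

Compound 1 `O=C(COc1ccc(/C=C2\SC(=O)NC2=O)cc1)Nc1ccc(Cl)cc1` carries 4-chlorophenyl on the amide-type nitrogen, and in a functional assay on PC-3 cells (Homo sapiens) for inhibition (a lower number here means a stronger inhibitor of growth, a higher number a weaker inhibitor of growth), compound 1 gives 83400 nM. Compound 2 `Cc1cc(Br)ccc1NC(=O)COc1ccc(/C=C2\SC(=O)NC2=O)cc1` carries 4-bromo-2-methylphenyl in the same place. In this assay compound 2 reaches only a limit of the assay, > 100000 nM, so for compound 2 a limit rather than a number is known. Going by the values given here, the single measured step, an at least 1.1-fold higher number from compound 1 to compound 2 (0.07 log units; that floor lies within the scatter), is thus a floor with no upper edge; the limit of > 100000 nM in this assay, at which 1 of the 2 values shown sits, marks where compound 2 sits. Compound 3 `O=C(COc1ccc(/C=C2\SC(=O)NC2=O)cc1)Nc1c(Cl)cccc1Cl` differs from compound 2 by 2,6-dichlorophenyl in place of 4-bromo-2-methylphenyl on an amide-type nitrogen. Among the compounds with values here, the only step bearing on this change is an at least 1.1-fold higher number from compound 1 to compound 2 (0.07 log units; that floor lies within the scatter), and it shows no downward movement on swapping the aryl group on the amide-type nitrogen. Compound 3 is therefore expected to remain in the same weak region, with a step that the limit leaves unreadable from compound 2 to compound 3 estimated as no step beyond the scatter. For compound 3 the estimate in this assay is 110000 nM, ranging from 45000 nM to 300000 nM, most likely reported again as a limit.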

Compound 3, concentration for 50% growth inhibition: > 100000 nM
Compound 3 ended at the assay's limit (the forecaster's own chance of this, stated with the estimate: 60%); the middle value does not contradict the limit.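

In this assay compound 3 also stands at a limit of the assay rather than at a number: the limit of > 100000 nM in this assay, at which 2 of the 3 values shown sit.

Replacing 4-chlorophenyl with 2,6-dichlorophenyl on the amide-type nitrogen gives an at least 1.1-fold higher number from compound 1 to compound 3 (0.07 log units; that floor lies within the scatter), so a second aryl change at this position shows no downward movement in the number, and neither compound 2 nor compound 3 gives a readable gain over compound 1. The step between compound 2 and compound 3 cannot be read, so the 4-bromo-2-methylphenyl and 2,6-dichlorophenyl groups cannot be ranked against each other.

As far as these compounds go, how far compound 2 and compound 3 lie past the limit remains open. Also open, from the compounds shown here alone, is whether a carboxylic acid or an amine on this aryl group would bring a clearly lower number than compound 1 gives.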